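The source may report more compounds than this note shows. Statements on the series, on what has been measured and on what is new or still open speak of the compounds shown alone.

Compounds measured so far in a functional assay on SiHa cells (Homo sapiens) for cytotoxicity, read by MTT assay, with a stated time of 48 h; on this read-out lower numbers stand for stronger inhibition and higher numbers for weaker inhibition:
compound 1 `CCCCCCCCCCCCCCNC(=O)[C@@H](NS(=O)(=O)c1ccc2ccccc2c1)[C@@H](C)O` gives 11100 nM;
compound 2 `CCCCCCCCCCCCCCCCCCNC(=O)[C@@H](NS(=O)(=O)c1ccc(C)cc1)[C@@H](C)O` gives 29800 nM;
compound 3 `CCCCCCCCCCCCCCCCCCNC(=O)[C@@H](NS(=O)(=O)c1cccs1)[C@@H](C)O` gives > 200000 nM.

The value for compound 3 is a limit of this assay, not a number; it sits at the limit of > 200000 nM in this assay, at which 1 of the 3 values shown sits, so compound 3 stands at the weak end of everything measured here. Compound 4 `CCCCCCCCCCCCCCCCCCNC(=O)[C@@H](NS(=O)(=O)c1ccc2ccccc2c1)[C@@H](C)O` differs from compound 3 in one place: naphthalen-2-yl in place of thiophen-2-yl on a sulfonyl sulfur. Among the compounds with values here, only one measured step touches this position, the step of an at least 6.7-fold higher number from compound 2 to compound 3 (0.82 log units; beyond the scatter), which went toward weaker inhibition when thiophen-2-yl entered. Compound 4 reverses the thiophen-2-yl in the other direction, toward an aromatic group, and compound 1, which also carries naphthalen-2-yl on the sulfonyl sulfur, gives a number rather than a limit. The step from compound 3 to compound 4 is therefore expected to run toward stronger inhibition, estimated as an at least 10-fold lower number from compound 3 to compound 4 (1.00 log units; beyond the scatter) in this assay. For compound 4 the expected value in this assay is 20000 nM, with a range from 6000 nM to 70000 nM.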

Compound 4, half-maximal inhibitory concentration: 19900 nM
Estimate against measurement, compound 4: 1.0-fold (0.00 log units) above; measured number inside the range.
By their numbers in this assay, from the lowest: compounds 1, 4 and 2 (each within the scatter of the next, the first and the last beyond it). At a limit, above all of these: compound 3.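

In this assay, the group on the sulfonyl sulfur now has a second comparison with thiophen-2-yl: an at least 10-fold lower number from compound 3 to compound 4 (1.00 log units; beyond the scatter), so among compounds 2, 3 and 4 thiophen-2-yl alone stands apart. Within the data shown here, the two larger aromatic groups are not told apart, a 1.5-fold lower number from compound 2 to compound 4 (0.18 log units; within the scatter), and the first comparison of chain length at a fixed naphthalen-2-yl shows no separation either, a 1.8-fold higher number from compound 1 to compound 4 (0.25 log units; within the scatter). The value of compound 3 is a limit of the assay and not a number: the limit of > 200000 nM in this assay, at which 1 of the 4 values shown sits.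

The compounds shown leave open whether an amine or a carboxylic acid on the aromatic group would keep the activity of compound 2 and compound 4. They also leave open how a chain much shorter than that of compound 1 would read in this assay.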